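This account rests on a few compounds, and the source may have more. Where it says the series, first, only, none or still open, it means among the compounds named here.

Measured so far in a functional assay on MDA-MB-231 cells (Homo sapiens) for antiproliferative activity, read by MTT assay, with a stated time of 72 h; on this read-out higher numbers stand for weaker inhibition and lower numbers for stronger inhibition:
- compound 1, `NC1=NC2(CCOCC2)N(OCCCOc2ccc(Cl)c(Cl)c2)C(N)=N1`, gives 590 nM
- compound 2, `NC1=NC2(CCOCC2)N(OCCCOc2ccccc2Br)C(N)=N1`, gives 910 nM

Compound 2 stands at the top of these two numbers, but the distance is small: going from compound 1 to compound 2, the number rises by a 1.5-fold higher number from compound 1 to compound 2 (0.19 log units; within the scatter), a gap within the usual scatter, so the two compounds cannot be told apart on this read-out.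

Compound 3, `NC1=NC2(CCOCC2)N(OCCCOc2cccc(Cl)c2)C(N)=N1`, has not yet been measured. It differs from compound 2 in one place: 3-chlorophenyl in place of 2-bromophenyl on an oxygen on a saturated carbon. For the measured compounds named here, the phenoxy group on the oxygen on a saturated carbon is the only part that changes; the shared core and the chain to it are untouched.

Going by the values given here, the one measured step that bears on this is the exchange of one halogenated phenyl for another, from compound 1 to compound 2, which moved the number by only a 1.5-fold higher number from compound 1 to compound 2 (0.19 log units; within the scatter). Another exchange of the same kind is therefore expected to stay within the scatter in this assay, with no clear direction. For compound 3 a value of about 800 nM is estimated, most likely between 350 nM and 1800 nM, which means an expected step of a 1.1-fold lower number from compound 2 to compound 3 (0.06 log units; within the scatter).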

Compound 3, half-maximal inhibitory concentration: 1020 nM
Compound 3: middle estimate off by 1.3-fold (0.11 log units), on the low side; measured number inside the range.
By their numbers in this assay, from the lowest: compounds 1, 2 and 3 (each within the scatter of the next).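

In this assay, the exchange of 2-bromophenyl for 3-chlorophenyl gives a 1.1-fold higher number from compound 2 to compound 3 (0.05 log units; within the scatter), so a second swap of one halogenated phenyl for another also leaves the two compounds indistinguishable on this read-out. The new compound also adds a different kind of change, hydrogen in place of chloro on an aromatic carbon, which gives a 1.7-fold higher number from compound 1 to compound 3 (0.24 log units; within the scatter) and so is likewise too small to read as a real difference, even though the number of halogens on the ring is not the same. Across these three compounds, the phenyl group on the oxygen can therefore carry bromine or chlorine, one halogen or two, with no difference that can be told apart in this assay, and no measurement is available that could explain this lack of separation.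

On these data alone, what remains open is whether a phenyl with no halogen at all, or one carrying a methoxy group, an amine or a carboxylic acid, would stay as close to these three compounds. Also open, as far as these compounds go, is what a longer chain between the shared core and the phenoxy group would do to the number, as all three compounds have the same chain.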